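This account rests on a few compounds, and the source may have more. Where it says the series, first, only, none or still open, it means among the compounds named here.

Working notes on the series. All three measured compounds share one core and differ only in the group on a saturated chain carbon bound to an aromatic carbon. Compound 1 `O=C(O)c1ccccc1-c1ccc(CCc2ncc(Cc3ccccc3F)[nH]2)cc1` gives 9.5 nM in an in vitro functional assay on cells for agonist activity at Bombesin receptor subtype-3 (Mus musculus), read by luminescence and calcium flux; a lower number here means that less compound is needed, a higher number that more compound is needed for the effect. Compound 2 `O=C(O)c1ccccc1-c1ccc(CCc2ncc(Cc3cccc(Cl)c3)[nH]2)cc1` gives 31 nM in this assay, and compound 3 `O=C(O)c1ccccc1-c1ccc(CCc2ncc(CC3CCCCCC3)[nH]2)cc1` gives 5.7 nM in this assay. Among the three numbers compound 1 stands second highest: the nearest is compound 3, with a 1.7-fold lower number from compound 1 to compound 3 (0.22 log units; within the scatter), the furthest compound 2, with a 3.3-fold higher number from compound 1 to compound 2 (0.51 log units; beyond the scatter). Between the other two, a 5.4-fold lower number from compound 2 to compound 3 (0.74 log units; beyond the scatter).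

Compound 4 `N#Cc1ccccc1Cc1cnc(CCc2ccc(-c3ccccc3C(=O)O)cc2)[nH]1` is not yet measured in this assay. Relative to compound 1 the change is cyano in place of fluoro on an aromatic carbon. Within the data shown here, no measured step alters a substituent within the 2-fluorophenyl group itself; the two steps from compound 1 exchange the whole group, giving a modest rise in one case, a 3.3-fold higher number from compound 1 to compound 2 (0.51 log units; beyond the scatter), and a change within the scatter in the other, a 1.7-fold lower number from compound 1 to compound 3 (0.22 log units; within the scatter). Both stay in a narrow band, so for compound 4 the expected step in this assay is small, a 1.6-fold higher number from compound 1 to compound 4 (0.20 log units; within the scatter), and may not exceed the scatter. The estimate for compound 4 in this assay is 15 nM, with a range from 5 nM to 45 nM.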

Compound 4, half-maximal effective concentration: 642 nM
For compound 4 the middle estimate is 43-fold (1.63 log units) below the measured one; the whole stated range lies below it.
By their numbers in this assay, from the lowest: compounds 3 and 1 (each within the scatter of the next); then compound 2; then compound 4.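

In this assay, the exchange of fluoro for cyano on an aromatic carbon ortho to a large group is the first change shown within the 2-fluorophenyl group rather than an exchange of the whole group, and it gives a 68-fold higher number from compound 1 to compound 4 (1.83 log units; beyond the scatter). Among these compounds, this single substituent change, with one heavy atom leaving and two entering, is a larger step than any exchange of the whole group among the earlier compounds, so the number at this position can depend strongly on the substituent on the aromatic ring and not only on the kind of group on the saturated chain carbon. The 2-cyanophenyl group also stands apart from the other two groups, with a 110-fold higher number from compound 3 to compound 4 (2.05 log units; beyond the scatter) and a 21-fold higher number from compound 2 to compound 4 (1.32 log units; beyond the scatter); no measurement in hand accounts for these steps.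

The compounds shown leave open whether this large rise is peculiar to the nitrile or also follows from other groups on this aromatic carbon, such as a methoxy group, a primary amide or a carboxylic acid. They also leave open whether a nitrile on another carbon of the same ring would give a step of similar size.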